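Adding a methyl group to compound 3

A few compounds are considered here, and "the series" means these few. Any claim that something is new, unique, unknown or untested is made for them only; others in the source may bear on it.

Values measured in a physicochemical assay for solubility, with a stated time of 24 h, at pH 6.8; on this read-out lower numbers stand for lower solubility and higher numbers for higher solubility:
- Compound 1 `COC(=O)c1ccc2ccc(C(=O)N(C)C)c-2cc1`: > 64 ug/mL (a limit)
- Compound 2 `COC(=O)c1ccc2c(C(=O)Nc3ccccc3)cn(C)c2c1`: < 1 ug/mL (a limit)
- Compound 3 `O=C(Cn1ccccc1=O)Nc1cc2ccccc2[nH]1`: > 67 ug/mL (a limit)

None of these three results is an exact number, so they place the compounds only roughly. Compound 3 stands at > 67 ug/mL, which is a limit of the assay. Compound 3 shares the high end of the three results with compound 1, while compound 2 sits alone at the low end.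

Compound 4 `Cn1c(NC(=O)Cn2ccccc2=O)cc2ccccc21` has not yet been measured. It matches compound 3 except in one place: methyl in place of hydrogen on an aromatic nitrogen. Within the data shown here, no measured pair here shows this change on its own, so its size in this assay cannot be read directly from the data.

With so small a change, compound 4 is expected to stay well away from the low end, and a modest fall is the likelier direction. The expected change an at least 1.4-fold lower number from compound 3 to compound 4 (0.17 log units; that floor lies within the scatter) is therefore small, and the result may again come back as a limit. For compound 4 the estimated solubility is 45 ug/mL, with an expected range of 12 ug/mL to 80 ug/mL.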

Compound 4, solubility: 3 ug/mL
Compound 4: the middle estimate sits 15-fold (1.18 log units) above what was measured; the whole stated range lies above it.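

In this assay, methyl in place of hydrogen on an aromatic nitrogen, next to the ring atom that bears a large group, gives an at least 22-fold lower number from compound 3 to compound 4 (1.34 log units; beyond the scatter), so a single added carbon at this position is enough to produce a large change. This pair gives the first direct view of the change, since compound 1 and compound 2 each differ from compound 3 in more than one place and could not show it on its own. The true drop may be larger still, and the printed size is only a floor, because the value of compound 3 is a limit of the assay rather than a number: the limit of > 67 ug/mL in this assay, at which 1 of the 4 values shown sits.

One pair cannot show what lies behind the drop, or whether it comes from the methyl group itself or from the loss of the hydrogen on that nitrogen. An ethyl group or a longer chain ending in an amine on the same nitrogen would test how the read-out responds to what sits there, and the same swap on a different core would test whether the effect reaches beyond this one pair.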